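The source may report more compounds than this note shows. Statements on the series, on what has been measured and on what is new or still open speak of the compounds shown alone.

Compound 1, `CNc1nn2cccnc2c1S(=O)(=O)c1ccccc1`, in a functional assay on HEK293 cells for antagonist activity at 5-hydroxytryptamine receptor 6 (Homo sapiens), read by cAMP accumulation, with a stated time of 2 h; a higher number here means a weaker inhibitor, a lower number a stronger inhibitor: 3.89 nM
Compound 2, `CSc1nn2c(C)cc(C)nc2c1S(=O)(=O)c1ccc(Cl)cc1`, in this assay: 3.16 nM
Compound 3, `CNc1nn2c(C)cc(C)nc2c1S(=O)(=O)c1ccc(F)cc1`, in this assay: 0.398 nM

Compound 3 stands at the lowest of the three numbers in this assay. Compound 2 lies well above it, and compound 1 farther still, both gaps beyond the usual scatter. Compound 4, `CNc1nn2c(C)cc(C)nc2c1S(=O)(=O)c1ccc(OC)cc1`, has not been measured. It differs from compound 3 in one place: methoxy in place of fluoro on an aromatic carbon. Among the compounds with values here, no pair of measured compounds shows this same change by itself, so the step can only be anticipated. The expected step, a 1.8-fold higher number from compound 3 to compound 4 (0.25 log units; within the scatter), is small and points toward a somewhat higher number, possibly staying within the scatter. For compound 4 the estimated value in this assay is 0.7 nM, with a likely range from 0.25 nM to 2.5 nM.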

Compound 4, inhibition constant: 9.55 nM
Compound 4: middle estimate off by 14-fold (1.13 log units), on the low side; the whole stated range lies below it.
By their numbers in this assay, from the lowest: compound 3; then compounds 2 and 1 (each within the scatter of the next); then compound 4.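

In this assay, changing 4-fluorophenyl to 4-methoxyphenyl gives a 24-fold higher number from compound 3 to compound 4 (1.38 log units; beyond the scatter) and this is a large step. Within the data shown here, it is the first comparison here in which only one place differs, and it shows that the group on this aromatic carbon can strongly change the number, with fluoro giving the lower value of this pair. Nothing available here accounts for the size of this step.

Among these compounds, with only this pair at this position, no trend across groups can be drawn. From the compounds shown here alone, how an amine, a nitrile or a longer chain such as ethoxy would compare on the same core remains open.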